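Ring size of the amine and monoamine oxidase A inhibition

The source may report more compounds than this note shows. Statements on the series, on what has been measured and on what is new or still open speak of the compounds shown alone.

Compound 3 `Cc1cc(O)cc2oc(=O)c(C(=O)CCN3CCCCC3)cc12` is the only one of the three measured compounds to give a number in an assay on cells for inhibition of Amine oxidase [flavin-containing] A (Homo sapiens), read by fluorescence, spectrophotometry and Amplex Red, with stated times of 60 min and 30 min; a lower number here means a stronger inhibitor, a higher number a weaker inhibitor: compound 3 gives 136000 nM. Compound 1 `O=C(CCN1CCCC1)c1cc2ccc(O)cc2oc1=O` reaches only a limit there, > 200000 nM. Compound 2 `Cc1cc(O)cc2oc(=O)c(C(=O)CCN(C)C)cc12` likewise sits at a limit, > 200000 nM. Going by the values given here, the step of an at least 1.4-fold lower number from compound 2 to compound 3 (0.16 log units; that floor lies within the scatter) is the one measured change of the amine, and its floor rests on (the limit of > 200000 nM in this assay, at which 2 of the 3 values shown sit). Compound 4 `Cc1cc(O)cc2oc(=O)c(C(=O)CCN3CCCC3)cc12` differs from compound 3 by pyrrolidin-1-yl in place of piperidin-1-yl on a saturated chain carbon, two bonds along the chain from a carbonyl carbon. Among the compounds with values here, only that amine step bears on this change, and it was small, so no step beyond the scatter is expected in this assay. The expected step is a 1.3-fold higher number from compound 3 to compound 4 (0.12 log units; within the scatter). Compound 4 is estimated to give 180000 nM, between 90000 nM and 400000 nM, with a fair chance of only a limit.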

Compound 4, half-maximal inhibitory concentration: 173000 nM
Estimate against measurement, compound 4: 1.0-fold (0.02 log units) above, within the range that was stated.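

In this assay the step of a 1.3-fold higher number from compound 3 to compound 4 (0.10 log units; within the scatter) leaves pyrrolidin-1-yl and piperidin-1-yl at this place, on a saturated chain carbon, not told apart by ring size. The steps of an at least 1.1-fold lower number from compound 2 to compound 4 (0.06 log units; that floor lies within the scatter) and an at least 1.1-fold lower number from compound 1 to compound 4 (0.06 log units; that floor lies within the scatter) give only floors, so neither pyrrolidin-1-yl in place of dimethylamino nor methyl in place of hydrogen on an aromatic carbon is shown to change the number, and both floors rest on a limit: the limit of > 200000 nM in this assay, at which 2 of the 4 values shown sit.

Going by these compounds, whether a morpholin-4-yl group at this place would give a step beyond the scatter stays open. The same holds for a longer chain between the carbonyl carbon and the amine.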